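Chloro in place of methoxy in compound 1

This account rests on a few compounds, and the source may have more. Where it says the series, first, only, none or still open, it means among the compounds named here.

Within the data shown here, in a functional assay on HeLa cells (Homo sapiens) for antiproliferative activity, read by cell counting, with a stated time of 2 days (a lower number here means a stronger inhibitor, a higher number a weaker inhibitor), compound 1 `COc1ccc(Nc2nc(N)c(C(=O)c3ccccc3)s2)cc1` gives 230 nM as the higher of the two numbers so far. Among the measured compounds shown here, compound 2 `COc1ccc(Nc2nc(N)c(C(=O)c3ccc(Cl)cc3)s2)cc1` gives 83 nM and is its only neighbour. For the measured compounds named here, the single measured step is a 2.8-fold lower number from compound 1 to compound 2 (0.44 log units; beyond the scatter) for chloro in place of hydrogen on an aromatic carbon, which is modest but beyond the scatter. Compound 3 `Nc1nc(Nc2ccc(Cl)cc2)sc1C(=O)c1ccccc1` carries a different change, chloro in place of methoxy on an aromatic carbon with chloro in place of methoxy on an aromatic carbon, para to a large group. The step to compound 2 lies at another site and removes no methoxy, so it offers only a rough size and no direction. No shift beyond the scatter is therefore expected in this assay for this change. The expected step is a 1.3-fold higher number from compound 1 to compound 3 (0.12 log units; within the scatter) within a wide margin. For compound 3 the estimated value is 300 nM with an expected range from 80 nM to 1000 nM as its limits.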

Compound 3, half-maximal inhibitory concentration: > 10000 nM
Compound 3 gave a limit, no number; the forecaster's own chance of this, stated with the estimate: 3%; middle value at least 33-fold (1.52 log units) from the limit.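

Chloro in place of methoxy at this position, para to a large group, gives an at least 43-fold higher number from compound 1 to compound 3 (1.63 log units; beyond the scatter) in this assay, whereas chloro in place of hydrogen at the other site gives only a 2.8-fold lower number from compound 1 to compound 2 (0.44 log units; beyond the scatter). Going by these compounds, compound 3 gives a limit and not a number, so the full size of its step stays unknown: the limit of > 10000 nM in this assay, at which 1 of the 3 values shown sits. The swap takes away the one hydrogen-bond acceptor of the methoxy group, but the data do not show whether that loss or the arrival of chloro accounts for the result.

Still open, on these data alone, is whether the methoxy group as a whole is needed here or whether a hydroxy group, an amine or an ethoxy group would serve in its place. With only two groups shown at this position, no trend across groups can be claimed.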